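The source may report more compounds than this note shows. Statements on the series, on what has been measured and on what is new or still open speak of the compounds shown alone.

Within the data shown here, compound 2, `CC(C)(C)NCc1c(C(=O)O)nn(-c2ccccc2)c1-c1ccc(Cl)cc1`, stands as the only compound here with a single number in a functional assay on K562 cells (Homo sapiens) for inhibition, read by sulforhodamine B assay, with a stated time of 48 h (a higher number here means a weaker inhibitor of growth, a lower number a stronger inhibitor of growth), where compound 2 gives 364000 nM. Compound 1, `CCOC(=O)c1nn(-c2ccccc2)c(-c2ccc(C)cc2)c1CNC(C)(C)C`, has several entries in this assay, 11300 nM; > 585000 nM (2 entries), and these entries do not agree with one another. Compound 3, `Cc1ccc(-c2c(CNC(C)(C)C)c(C(=O)O)nn2-c2ccccc2)cc1`, differs from compound 2 by methyl in place of chloro on an aromatic carbon. No step between measured compounds is shown, and compound 1 differs from compound 3 in more than one place, so no direct guide exists. The expected step is a 1.2-fold lower number from compound 2 to compound 3 (0.08 log units; within the scatter), within the scatter. Compound 3 is therefore estimated at 300000 nM, in the range 60000 nM to 600000 nM.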

Compound 3, concentration for 50% growth inhibition: > 688000 nM
Compound 3 was reported as a limit (the forecaster's own chance of this, stated with the estimate: 35%); at least 2.2-fold (0.36 log units) between middle value and limit.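

In this assay, among these compounds, the change from 4-chlorophenyl to 4-methylphenyl gives the first direct comparison at this position: an at least 1.8-fold higher number from compound 2 to compound 3 (0.27 log units; that floor lies within the scatter). Nothing in this step points to stronger growth inhibition with methyl in place of chloro, though the floor of the step does not establish a real loss either. Compound 3 is reported only as a limit, so the full size of the step cannot be read: the limit of > 688000 nM in this assay, at which 1 of the 3 values shown sits.

The compounds shown leave open whether a methoxy or a fluoro group on this aromatic carbon would give a lower number.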